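From compound 3 to compound 4: one group exchanged

The source may report more compounds than this note shows. Statements on the series, on what has been measured and on what is new or still open speak of the compounds shown alone.

Three measured compounds share one core and differ in the group on a carbonyl carbon. In a physicochemical assay for solubility (on this read-out lower numbers stand for lower solubility and higher numbers for higher solubility), compound 1 `O=C(CN1CCCC1)N1CCC(NS(=O)(=O)c2cc(S(=O)(=O)c3ccccc3)ccc2C(F)(F)F)CC1` gives 25000 nM, and compound 2 `CC(C)(C)OC(=O)N1CCC[C@H]1C(=O)N1CCC(NS(=O)(=O)c2cc(S(=O)(=O)c3ccccc3)ccc2C(F)(F)F)CC1` gives 25000 nM. Compound 3 `O=C1CC[C@@H](C(=O)N2CCC(NS(=O)(=O)c3cc(S(=O)(=O)c4ccccc4)ccc3C(F)(F)F)CC2)N1` stands highest of the three at 100000 nM.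

The next compound, compound 4 `CC(C)(C)C(=O)N1CCC[C@H]1C(=O)N1CCC(NS(=O)(=O)c2cc(S(=O)(=O)c3ccccc3)ccc2C(F)(F)F)CC1`, has not yet been measured. It carries 1-((tert-butyl)carbonyl)pyrrolidin-2-yl in place of 5-oxopyrrolidin-2-yl on a carbonyl carbon.

The closest measured change is a 4.0-fold higher number from compound 2 to compound 3 (0.60 log units; beyond the scatter), where 5-oxopyrrolidin-2-yl replaced 1-(tert-butoxycarbonyl)pyrrolidin-2-yl. The change to compound 4 runs the opposite way, to a closely related group, though this exact group has no measurement. The other measured change to 5-oxopyrrolidin-2-yl is a 4.0-fold higher number from compound 1 to compound 3 (0.60 log units; beyond the scatter), while no change at the digits printed from compound 1 to compound 2 (within the scatter) shows that the two groups it can be compared with sit together.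

A step of similar size towards a lower number is therefore expected in this assay. The expected step is a 3.7-fold lower number from compound 3 to compound 4 (0.57 log units; beyond the scatter). For compound 4 the estimate is 27000 nM, with an expected range of 11000 nM to 65000 nM.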

Compound 4, solubility: 50000 nM
Estimate against measurement, compound 4: 1.9-fold (0.27 log units) below; measured number inside the range.
By their numbers in this assay, from the lowest: compounds 1, 2, 4 and 3 (each within the scatter of the next, the first and the last beyond it).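

In this assay, the step of a 2.0-fold lower number from compound 3 to compound 4 (0.30 log units; within the scatter) does not separate 1-((tert-butyl)carbonyl)pyrrolidin-2-yl, with 11 heavy atoms and 0 hydrogen-bond donors, from 5-oxopyrrolidin-2-yl, with 6 heavy atoms and 1 hydrogen-bond donor. The step of a 2.0-fold higher number from compound 1 to compound 4 (0.30 log units; within the scatter) is also within the scatter, so compound 4 cannot be placed on either side of the earlier gap, which set compound 3 apart from compound 1 and compound 2. Exchanging only tert-butoxy for tert-butyl on the carbonyl carbon gives a 2.0-fold higher number from compound 2 to compound 4 (0.30 log units; within the scatter), again a step that repeat measurements alone could produce.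

No measurement here offers an explanation for these numbers. On these data alone, whether a group ending in a carboxylic acid, placed on this carbonyl carbon, would stand clear of compound 3 remains open.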